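Thiourea Aryl Swap on a Shared Thienopyridine Amide Core

The source may report more compounds than this note shows. Statements on the series, on what has been measured and on what is new or still open speak of the compounds shown alone.

Measured compounds:
compound 1 `NC(=O)c1c(NC(=O)c2ccccc2Cl)sc2c1CCN(C(=S)Nc1cccc3ccccc13)C2`, 30800 nM
compound 2 `NC(=O)c1c(NC(=O)c2ccccc2Cl)sc2c1CCN(C(=S)Nc1ccccc1I)C2`, 29000 nM

In a functional assay on HeLa cells (Homo sapiens) for antiproliferative activity, with a stated time of 24 h (on this read-out lower numbers stand for stronger inhibition and higher numbers for weaker inhibition), compound 1 gives 30800 nM. In this assay compound 2 gives 29000 nM, which is the lowest of the two numbers seen, though the step of a 1.1-fold lower number from compound 1 to compound 2 (0.03 log units; within the scatter) is within the scatter, so compound 2 and compound 1 cannot be ordered.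

Compound 3 `Cc1ccccc1NC(=S)N1CCc2c(sc(NC(=O)c3ccccc3Cl)c2C(N)=O)C1` differs from compound 2 by methyl in place of iodo on an aromatic carbon. Among the measured compounds shown here, the only measured step that bears on this position is a 1.1-fold lower number from compound 1 to compound 2 (0.03 log units; within the scatter), an exchange of the whole aryl group on the thiourea nitrogen that left the number unchanged within the scatter. A smaller exchange of one ortho substituent for another is therefore expected to produce no step beyond the scatter in this assay.

Compound 3 is estimated at 30000 nM, with a range from 12000 nM to 75000 nM. The expected step is a 1.0-fold higher number from compound 2 to compound 3 (0.01 log units; within the scatter), because a 1.1-fold lower number from compound 1 to compound 2 (0.03 log units; within the scatter) showed no change on a larger alteration at the same site.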

Compound 3, half-maximal inhibitory concentration: > 50000 nM
Compound 3: a limit, no number (the forecaster's own chance of this, stated with the estimate: 25%); at least 1.6-fold (0.22 log units) between middle value and limit.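

Compound 3 gives > 50000 nM in this assay, a limit of the assay and not a number, and the only such result among the compounds shown: the limit of > 50000 nM in this assay, at which 1 of the 3 values shown sits.

Methyl in place of iodo, one heavy atom for one, gives an at least 1.7-fold higher number from compound 2 to compound 3 (0.23 log units; that floor lies within the scatter), and 2-methylphenyl in place of naphthalen-1-yl gives an at least 1.6-fold higher number from compound 1 to compound 3 (0.21 log units; that floor lies within the scatter). The earlier pair offered two numbers at this position, whereas this change yields only a floor, and as both floors lie within the scatter, compound 3 cannot be ordered against compound 1 or compound 2.

On these data alone, how far the true number of compound 3 lies past the limit remains open. Also open, as far as these compounds go, is what other groups on this aromatic carbon would give, such as chloro, methoxy or an amine in place of the iodo.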